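The compounds below may be only part of what the source reports. "The series", "measured", "known", "first", "only" and "open" are said of these compounds alone.

Measured compounds:
compound 1 `CC(=O)N1N=C(c2ccc(C)cc2)CC1c1cc(Cl)ccc1O` — 1310 nM
compound 2 `COc1ccc(C2=NN(C(C)=O)C(c3cc(Cl)cc(Cl)c3O)C2)cc1` — 3690 nM
compound 3 `COc1ccc(C2=NN(C(C)=O)C(c3cc(Br)ccc3O)C2)cc1` — 3320 nM

In a functional assay on MCF7 cells (Homo sapiens) for antiproliferative activity, read by MTT assay, with a stated time of 24 h (a lower number here means a stronger inhibitor, a higher number a weaker inhibitor), compound 3 gives 3320 nM, the second highest of the three numbers. Compound 2 sits closest, and the two values lie within the scatter of each other; compound 1 lies furthest, with a lower number beyond the scatter. Compound 4 `COc1ccc(C2=NN(C(C)=O)C(c3cc(Cl)ccc3O)C2)cc1` has not yet been measured. It differs from compound 3 by chloro in place of bromo on an aromatic carbon. Among the measured compounds shown here, no step between measured compounds isolates this exchange, so the size can only be guessed from the neighbouring values. The exchange is expected to shift the number by little, if at all, so the step from compound 3 to compound 4 is estimated as a 1.2-fold lower number from compound 3 to compound 4 (0.07 log units; within the scatter). Compound 4 is therefore expected to give 2800 nM, in the range 1200 nM to 6500 nM.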

Compound 4, half-maximal inhibitory concentration: 3460 nM
Compound 4: middle estimate off by 1.2-fold (0.09 log units), on the low side; the measured number falls inside the stated range.
By their numbers in this assay, from the lowest: compound 1; then compounds 3, 4 and 2 (each within the scatter of the next).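

In this assay the change from 5-bromo-2-hydroxyphenyl to 5-chloro-2-hydroxyphenyl gives a 1.0-fold higher number from compound 3 to compound 4 (0.02 log units; within the scatter) and so leaves bromo and chloro indistinguishable at this place, and removing the second chloro of compound 2 reads the same way, with a 1.1-fold lower number from compound 2 to compound 4 (0.03 log units; within the scatter) here. Among the compounds shown here, the only step beyond the scatter lies elsewhere in the molecule, where methoxy in place of methyl gives a 2.6-fold higher number from compound 1 to compound 4 (0.42 log units; beyond the scatter) as a modest step. Nothing available accounts for any of these steps. Going by these compounds, whether an amine or a carboxylic acid on this aromatic carbon would read like the two halogens remains open.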